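Side-chain sulfone to amide: cytotoxicity working notes

This account rests on a few compounds, and the source may have more. Where it says the series, first, only, none or still open, it means among the compounds named here.

Measured so far:
- compound 1, `CS(=O)(=O)CCCn1c(Cn2c(=O)n(C3CC3)c3ccncc32)cc2cc(Cl)ccc21`, gives > 50000 nM in an ADME assay on HeLa cells (Homo sapiens) for cytotoxicity, read by ATP content, with a stated time of 3 days; a lower number here means that less compound is tolerated, a higher number that more compound is tolerated
- compound 2, `CS(=O)(=O)CCCn1c(Cn2c(=O)n(C3CC3)c3ccncc32)cc2cc(C(F)(F)F)ccc21`, gives > 50000 nM in this assay
- compound 3, `CS(=O)(=O)CCCn1c(Cn2c(=O)n(C3CC3)c3ccncc32)cc2cc(F)ccc21`, gives > 50000 nM in this assay

Compound 1 stands at a limit in this assay and not at a number. The same holds across the whole set: the limit of > 50000 nM in this assay, at which 3 of the 3 values shown sit. The three measured steps, a step that the two limits leave unreadable from compound 1 to compound 2, a step that the two limits leave unreadable from compound 1 to compound 3 and a step that the two limits leave unreadable from compound 2 to compound 3, all exchange the substituent on the aromatic carbon of the shared core and none of them can be read in size, since both ends sit at the limit.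

Compound 4, `NC(=O)CCCn1c(Cn2c(=O)n(C3CC3)c3ccncc32)cc2cc(Cl)ccc21`, is not yet measured. It differs from compound 1 in the side chain: carbamoyl in place of methylsulfonyl on a saturated chain carbon, three bonds along the chain from an aromatic nitrogen. Among the compounds with values here, no measured step touches this chain, so nothing among the measured compounds speaks directly to the change. What the data do show is that three substitutions on the aromatic carbon all left the tolerated concentration at the limit, so the baseline of the series in this assay is a limit rather than a number.

For compound 4 the expected step is a step that the limit leaves unreadable from compound 1 to compound 4, that is, no change beyond the scatter. Compound 4 is therefore estimated at 80000 nM in this assay, with a range from 30000 nM to 300000 nM, most likely reported again as a limit.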

Compound 4, half-maximal cytotoxic concentration: > 50000 nM
Compound 4 gave a limit, no number; the forecaster's own chance of this, stated with the estimate: 85%; the middle value lies beyond the limit too.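

No size can be read for the exchange of methylsulfonyl for carbamoyl from compound 1 to compound 4, as both values are limits and not numbers: the limit of > 50000 nM in this assay, at which 4 of the 4 values shown sit.

The compounds shown leave open where the half-maximal cytotoxic concentration of any of the four compounds lies, and whether either the side chain or the aromatic substituent shifts it.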